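Naphthyl replaces bromophenyl on the shared core

This account rests on a few compounds, and the source may have more. Where it says the series, first, only, none or still open, it means among the compounds named here.

Two compounds of the series have been run in a functional assay on COLO 205 cells (Homo sapiens) for inhibition, read by sulforhodamine B assay, tested at 10 uM; a lower number here means less inhibition of growth, a higher number more inhibition of growth at the concentration tested. Compound 1 `COc1cc(C2CC(c3ccc(OCc4cn(Cc5ccc([N+](=O)[O-])cc5)nn4)cc3)=NN2C(C)=O)ccc1Oc1cn(Cc2ccc([N+](=O)[O-])cc2)nn1` gives 27%, and compound 2 `COc1cc(C2CC(c3ccc(Br)cc3)=NN2C(C)=O)ccc1OCc1cn(Cc2ccc([N+](=O)[O-])cc2)nn1` gives 26%. The two numbers lie within the scatter of each other, so no ranking between compound 1 and compound 2 can be read from them; both show modest growth inhibition at the concentration tested.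

The next compound, compound 3 `COc1cc(C2CC(c3cccc4ccccc34)=NN2C(C)=O)ccc1OCc1cn(Cc2ccc([N+](=O)[O-])cc2)nn1`, differs from compound 2 in one place: naphthalen-1-yl in place of 4-bromophenyl on a carbon with a double bond to nitrogen. Among the measured compounds shown here, no measured pair changes this part of the molecule, so there is no step to rest on.

In the absence of such a step, compound 3 is expected to stay near compound 2, with a step of a number 2 percentage points higher from compound 2 to compound 3 (within the scatter) that is not expected to exceed the scatter. Compound 3 is estimated at 28% in this assay, within a range from 12% to 45%.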

Compound 3, percent growth inhibition at one concentration: 46%
Compound 3: the middle estimate sits 18 percentage points below what was measured; measured number above the stated range.
By their numbers in this assay, from the lowest: compounds 2 and 1 (each within the scatter of the next); then compound 3.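

Among the compounds shown here, this position on the carbon with a double bond to nitrogen turns out to be sensitive to the group it carries: in this assay naphthalen-1-yl in place of 4-bromophenyl gives a number 20 percentage points higher from compound 2 to compound 3 (beyond the scatter) and is the first change that can be read at a single place. The change takes out bromine and brings in a second six-membered aromatic ring of carbon only, and this one step cannot separate those two differences. Nothing at hand explains the rise in growth inhibition.

The compounds shown leave open whether the second ring or the loss of bromine carries the step; plain phenyl and naphthalen-2-yl at this position would bear on that. Also open, going by these compounds, is whether a quinolin-8-yl group or a dimethylamino-bearing phenyl would be tolerated here.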